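Kallikrein-7 series: removing the trifluoromethyl from compound 3

The source may hold more compounds than are shown below. What is called first, only, known or untested is meant among the compounds shown, and "the series" means these compounds.

Compound 3 `CN(C)/N=C1/CN(CC(=O)Nc2cccc(-c3cnn(C)c3)c2)C(=O)C(Cc2c(F)cccc2C(F)(F)F)CN1` sits at the limit of an assay on isolated protein for inhibition of kallikrein-7 (Mus musculus), read by fluorescence, with stated times of 10 min and 30 min (a higher number here means a weaker inhibitor, a lower number a stronger inhibitor), giving > 30000 nM, which is a limit of the assay and not a number; it is the one case where the assay reports only a bound (the limit of > 30000 nM in this assay, at which 1 of the 3 values shown sits). Compound 1 `CN(C)/N=C1/CN(CC(=O)Nc2cccc(-c3cnn(C)c3)c2)C(=O)C(Cc2c(F)cccc2Cl)CN1` gives 6000 nM in this assay, and compound 2 `Cc1cccc(F)c1CC1CN/C(=N\N(C)C)CN(CC(=O)Nc2cccc(-c3cnn(C)c3)c2)C1=O` gives 7700 nM. The steps among these three show that swapping chloro for methyl on the aromatic carbon changes little, a 1.3-fold higher number from compound 1 to compound 2 (0.11 log units; within the scatter), whereas placing trifluoromethyl there costs potency, an at least 5.0-fold higher number from compound 1 to compound 3 (0.69 log units; beyond the scatter) and an at least 3.8-fold higher number from compound 2 to compound 3 (0.59 log units; beyond the scatter).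

Compound 4 `CN(C)/N=C1/CN(CC(=O)Nc2cccc(-c3cnn(C)c3)c2)C(=O)C(Cc2ccccc2Cl)CN1` differs from compound 3 by 2-chlorophenyl in place of 2-fluoro-6-(trifluoromethyl)phenyl on a saturated chain carbon bound to a saturated ring carbon. Within the data shown here, this undoes the trifluoromethyl step and also drops the fluoro, so the most relevant measured step is the one from compound 1 to compound 3, read in reverse. Compound 4 is therefore expected to recover into the range of compound 1, an expected improvement of an at least 3.7-fold lower number from compound 3 to compound 4 (0.57 log units; beyond the scatter). The estimate for compound 4 in this assay is 8000 nM, with a range of 3000 nM to 25000 nM.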

Compound 4, half-maximal inhibitory concentration: 21000 nM
Compound 4: the middle estimate sits 2.6-fold (0.42 log units) below what was measured, and the stated range covers the measured number.
By their numbers in this assay, from the lowest: compounds 1 and 2 (each within the scatter of the next); then compound 4. At a limit, above all of these: compound 3.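

In this assay, among these compounds, the aromatic fluoro turns out to matter, which the earlier compounds, all of which keep it, could not show: hydrogen in its place gives a 3.5-fold higher number from compound 1 to compound 4 (0.54 log units; beyond the scatter) and the full ring change gives a 2.7-fold higher number from compound 2 to compound 4 (0.44 log units; beyond the scatter) on the same benzyl position. Chloro alone therefore does not carry the level of compounds 1 and 2. Removing trifluoromethyl and fluoro together gives an at least 1.4-fold lower number from compound 3 to compound 4 (0.15 log units; that floor lies within the scatter) as a floor only, so no recovery from compound 3 can be claimed, and its reading remains a limit: the limit of > 30000 nM in this assay, at which 1 of the 4 values shown sits.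

Among the compounds shown here, open is whether fluoro is the only group that serves here, or whether a methoxy or a nitrile in its place does as well. Also open, on these data alone, is what an unsubstituted phenyl or a 2-fluorophenyl on this chain carbon would give.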